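From Fluorophenyl to Bromofluorobenzyl: Estimating Compound 3

The source may report more compounds than this note shows. Statements on the series, on what has been measured and on what is new or still open speak of the compounds shown alone.

compound 1 `CCCn1c(=O)[nH]c2nc(-c3ccc(S(=O)(=O)N4CCN(c5cccc(F)c5)CC4)cc3)[nH]c2c1=O`: 0.632 nM
compound 2 `CCCn1c(=O)[nH]c2nc(-c3ccc(S(=O)(=O)N4CCN(c5ccc(F)cc5)CC4)cc3)[nH]c2c1=O`: 0.644 nM

In an assay on CHO cells for displacement of a labelled ligand from adenosine receptor A2b (Homo sapiens), read by scintillation counting, with a stated time of 75 min, in the presence of a further agent that is not named here (a lower number here means a stronger inhibitor, a higher number a weaker inhibitor), compound 1 gives 0.632 nM, the lowest of the two numbers; compound 2 gives 0.644 nM, and the step of a 1.0-fold higher number from compound 1 to compound 2 (0.01 log units; within the scatter) lies within the scatter. Compound 3 `CCCn1c(=O)[nH]c2nc(-c3ccc(S(=O)(=O)N4CCN(Cc5ccc(Br)c(F)c5)CC4)cc3)[nH]c2c1=O` is not yet measured. It differs from compound 1 by 4-bromo-3-fluorobenzyl in place of 3-fluorophenyl on an amine nitrogen in a ring. Among the measured compounds shown here, no measured step covers a change of this kind; the only step known, a 1.0-fold higher number from compound 1 to compound 2 (0.01 log units; within the scatter), moves a fluorine on the same sort of group and stays within the scatter, so it gives little guidance. A modest weakening is therefore expected, with a wide range. For compound 3 the expected value is 1.5 nM, between 0.3 nM and 8 nM. The expected step is a 2.4-fold higher number from compound 1 to compound 3 (0.38 log units; beyond the scatter).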

Compound 3, inhibition constant: 0.473 nM
For compound 3 the middle estimate is 3.2-fold (0.50 log units) above the measured one; measured number inside the range.
By their numbers in this assay, from the lowest: compounds 3, 1 and 2 (each within the scatter of the next).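

In this assay, the group on the amine nitrogen can grow from a fluorophenyl to 4-bromo-3-fluorobenzyl with no change beyond the scatter: a 1.3-fold lower number from compound 1 to compound 3 (0.13 log units; within the scatter) and a 1.4-fold lower number from compound 2 to compound 3 (0.13 log units; within the scatter) are both small. The earlier compounds shown here showed only that moving a fluorine on the phenyl ring changed little, whereas this result extends that to a larger group carrying a bromine. No evidence here bears on why the numbers stay so close.

The compounds shown leave open how the bromine and the added carbon each contribute. Going by these compounds, whether a longer chain or an amine at this position would keep the number in this range also remains open.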